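Series notes: remote aryl swap and amine acid dissociation

The source may hold more compounds than are shown below. What is called first, only, known or untested is meant among the compounds shown, and "the series" means these compounds.

Compound 1 `COc1ccc(F)cc1CNCCCNc1ccnc2cc(Cc3ccc(F)cc3Cl)ccc12` is the reference in a physicochemical assay for acid dissociation, where compound 1 gives 9.47. Compound 2 `Fc1ccc(Cc2ccc3c(NCCCNCc4ccco4)ccnc3c2)c(Cl)c1` gives 9.47, and compound 3 `COc1ccc(Oc2ccc3c(NCCCNCc4ccco4)ccnc3c2)cc1` gives 9.28. Compound 1 thus stands level with compound 2 at the digits shown, the two together the highest of the three numbers, with compound 3 the furthest off; the step of a number 0.19 log units lower from compound 2 to compound 3 (within the scatter) is within the scatter, as is the step of no change at the digits printed from compound 1 to compound 2 (within the scatter).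

Compound 4 `COc1ccc(F)cc1CNCCCNc1ccnc2cc(CCc3ccccc3)ccc12` differs from compound 1 as follows: benzyl in place of 2-chloro-4-fluorophenyl on a saturated chain carbon bound to an aromatic carbon. For the measured compounds named here, two measured steps bear on this. The step of a number 0.19 log units lower from compound 2 to compound 3 (within the scatter) replaced the group on that same aromatic carbon of the shared core, and the step of no change at the digits printed from compound 1 to compound 2 (within the scatter) altered the group at the other end of the chain; both lie within the scatter, so neither side of the molecule has yet moved the read-out. The expected step is therefore a number 0.02 log units lower from compound 1 to compound 4 (within the scatter), with no change beyond the scatter in either direction. Compound 4 is estimated at 9.45, within a range of 9.15 to 9.75.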

Compound 4, acid dissociation constant: 9.47
Compound 4: the middle estimate sits 0.02 log units below what was measured, and the stated range covers the measured number.
By their numbers in this assay, from the lowest: compounds 3, 1, 2 and 4 (each within the scatter of the next).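

In this assay, the result at this position is no change at the digits printed from compound 1 to compound 4 (within the scatter), with the 5-fluoro-2-methoxyphenyl end held fixed and a halogen-bearing 2-chloro-4-fluorophenyl giving way to an all-carbon benzyl. For the compounds shown here, the earlier step on the aromatic carbon of the core, a number 0.19 log units lower from compound 2 to compound 3 (within the scatter), did not test this chain carbon, so this pair is the first to show that losing both the chlorine and the fluorine, in the change read further out as 2-chloro-4-fluorobenzyl to phenethyl, leaves the number within the scatter. No supporting data offer an explanation for this result.

As far as these compounds go, it remains open whether an amine or a carboxylic acid on this chain carbon, in place of the benzyl, would give a step beyond the scatter. From the compounds shown here alone, a longer chain in place of the phenethyl is equally open.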